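Adding a Methoxy Group: An Expected Cytotoxicity for Compound 4

This account rests on a few compounds, and the source may have more. Where it says the series, first, only, none or still open, it means among the compounds named here.

Of the compounds shown here, three have so far been tested in an ADME assay on HEK293 cells (Homo sapiens) for cytotoxicity, read by MTT assay, with a stated time of 3 days; on this read-out lower numbers stand for stronger inhibition and higher numbers for weaker inhibition. Compound 1 `COc1ccccc1-c1cccc(O)c1` gives 50 ug/mL in this assay. Compound 2 `COc1ccc(-c2ccccc2)cc1` gives 17 ug/mL in this assay. Compound 3 `COc1ccc(-c2cccc(O)c2)c(OC)c1` gives 28 ug/mL in this assay. Compound 2 has the lowest of the three numbers, though its gap to compound 3 lies within the scatter, and only its gap to compound 1 lies beyond it.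

Compound 1 and compound 3 differ in a single place: methoxy in place of hydrogen on an aromatic carbon That change gave a 1.8-fold lower number from compound 1 to compound 3 (0.25 log units; within the scatter). The difference between the cores of compound 1 and compound 2 is not broken down here.

Compound 4 `COc1ccc(-c2ccccc2)cc1OC` has not yet been measured. It differs from compound 2 in one place: methoxy in place of hydrogen on an aromatic carbon This is the same kind of change as that from compound 1 to compound 3, but the surroundings differ. In the earlier pair the new group sits meta to a methoxy group and para to a group of 7 heavy atoms; here it sits ortho to a methoxy group and meta to a group of 6 heavy atoms.

In this assay the step is expected to be a 1.4-fold lower number from compound 2 to compound 4 (0.15 log units; within the scatter) because the same kind of change gave a 1.8-fold lower number from compound 1 to compound 3 (0.25 log units; within the scatter). Compound 4 is therefore estimated at 12 ug/mL in this assay, with a likely range from 6 ug/mL to 30 ug/mL.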

Compound 4, half-maximal inhibitory concentration: 26 ug/mL
Compound 4: the middle estimate sits 2.2-fold (0.34 log units) below what was measured, within the range that was stated.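

In this assay, the methoxy change made on compound 2's core, where the new group sits ortho to a methoxy group and meta to a group of 6 heavy atoms, gave a 1.5-fold higher number from compound 2 to compound 4 (0.18 log units; within the scatter). Taken alone, that step is small enough to be ordinary scatter, but set beside the earlier step it shows that this change did not carry over from one core to the other as the same step, and the gap between the two steps is too wide to put down to scatter: the same change on two cores in this assay, a 1.8-fold lower number (0.25 log units; within the scatter) from compound 1 to compound 3 and a 1.5-fold higher number (0.18 log units; within the scatter) from compound 2 to compound 4, 2.7-fold (0.44 log units) apart, beyond the scatter of two such steps. This does not show that the methoxy group itself pushes the number one way or the other, as each step alone lies within the scatter, and two pairs cannot tell which difference between the cores or the surroundings of the new group matters, nor do they give a rule for other cores in this series.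

The compounds shown leave open whether another group in the same place, such as an ethoxy group, an amine or a carboxylic acid, would give a step of similar size on both cores. They also leave open how the methoxy change would read on a third core.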